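Pyrrolidinyl for dimethylamino on the hydroxymethyl-bearing analogue

The source may report more compounds than this note shows. Statements on the series, on what has been measured and on what is new or still open speak of the compounds shown alone.

Working notes on two measured compounds and one pending. Among the compounds with values here, compound 1 `OC1CNCc2nc(-c3ccc(N4CCCC4)cc3)sc21` and compound 2 `CN(C)c1ccc(-c2nc3c(s2)C(O)CNC3)c(CO)c1` share a core but differ at more than one place, so no single step links them. In a functional assay on cells (Homo sapiens) for cytotoxicity, read by sulforhodamine B assay, with a stated time of 2 days (on this read-out lower numbers stand for stronger inhibition and higher numbers for weaker inhibition), compound 1 gives 1070 nM. In this assay compound 2 gives 100 nM, the lowest of the two numbers, with compound 1 standing at a higher number beyond the usual scatter. Compound 3 `OCc1cc(N2CCCC2)ccc1-c1nc2c(s1)C(O)CNC2` is not yet measured. It differs from compound 2 by pyrrolidin-1-yl in place of dimethylamino on an aromatic carbon; in words, pyrrolidin-1-yl in place of dimethylamino on an aromatic carbon. Within the data shown here, no measured pair isolates this exchange, so the size of the step in this assay is open; a step not beyond the usual scatter, in either direction, is expected. Compound 3 is therefore estimated at 120 nM, with a range of 40 nM to 400 nM. The expected step of a 1.2-fold higher number from compound 2 to compound 3 (0.08 log units; within the scatter) is small.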

Compound 3, half-maximal inhibitory concentration: 60 nM
The estimate for compound 3 lay 2.0-fold (0.30 log units) above the measured number, within the range that was stated.
By their numbers in this assay, from the lowest: compounds 3 and 2 (each within the scatter of the next); then compound 1.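

Within the data shown here, compound 3 gives the first single-place reading at this aromatic carbon: in this assay, pyrrolidin-1-yl in place of dimethylamino gives a 1.7-fold lower number from compound 2 to compound 3 (0.22 log units; within the scatter), so the ring and the open-chain amine are not separated here. It also isolates hydroxymethyl in place of hydrogen with pyrrolidin-1-yl held constant, giving an 18-fold lower number from compound 1 to compound 3 (1.25 log units; beyond the scatter), a step well beyond that of the amine exchange. No measurement shown accounts for either step.

As far as these compounds go, whether the hydroxymethyl step is of similar size with dimethylamino in place of pyrrolidin-1-yl remains open, as does the outcome with piperidin-1-yl or morpholin-4-yl at the same aromatic carbon. Also open, from the compounds shown here alone, is whether methoxymethyl or a carboxylic acid in place of hydroxymethyl would retain the step.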